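Series notes: thiophen-2-yl to 4-methoxyphenyl

The source may report more compounds than this note shows. Statements on the series, on what has been measured and on what is new or still open speak of the compounds shown alone.

Measured in a functional assay on COLO 205 cells (Homo sapiens) for inhibition, read by sulforhodamine B assay, with a stated time of 48 h, tested at 50 uM (on this read-out higher numbers stand for more inhibition of growth at the one concentration tested and lower numbers for less inhibition of growth), so far:
- compound 1 `COc1ccc(/C=C/C(=O)/C=C/c2ccc(OCc3cn(CCCCCOc4cc(=O)oc5ccccc45)nn3)c(OC)c2)cc1OC` gives 43%
- compound 2 `COc1cc(/C=C/C(=O)/C=C/c2cccc3ccccc23)ccc1OCc1cn(CCCCCOc2cc(=O)oc3ccccc23)nn1` gives 40%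
- compound 3 `COc1cc(/C=C/C(=O)/C=C/c2cccs2)ccc1OCc1cn(CCCCCOc2cc(=O)oc3ccccc23)nn1` gives 30%

Compound 3 carries the lowest of the three numbers, the nearer gap being a number 10 percentage points lower from compound 2 to compound 3 (within the scatter). Compound 4 `COc1ccc(/C=C/C(=O)/C=C/c2ccc(OCc3cn(CCCCCOc4cc(=O)oc5ccccc45)nn3)c(OC)c2)cc1` puts 4-methoxyphenyl in place of thiophen-2-yl on a double-bonded chain carbon bound to a double-bonded chain carbon, as follows: 4-methoxyphenyl in place of thiophen-2-yl on a double-bonded chain carbon bound to a double-bonded chain carbon. The closest measured group is the 3,4-dimethoxyphenyl of compound 1, so the step that bears most, read backwards, is a number 13 percentage points lower from compound 1 to compound 3 (beyond the scatter). Changing that group also gave a number 3 percentage points lower from compound 1 to compound 2 (within the scatter). A modest upward step is therefore expected, estimated as a number 10 percentage points higher from compound 3 to compound 4 (within the scatter). Compound 4 is expected at 40%, within 30% to 50%.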

Compound 4, percent growth inhibition at one concentration: 30%
The estimate for compound 4 lay 10 percentage points above the measured number; measured number inside the range.
By their numbers in this assay, from the lowest: compounds 3, 4, 2 and 1 (each within the scatter of the next, the first and the last beyond it).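

In this assay, 4-methoxyphenyl and thiophen-2-yl are not told apart at this position: no change at the digits printed from compound 3 to compound 4 (within the scatter). Replacing naphthalen-1-yl with 4-methoxyphenyl gives a number 10 percentage points lower from compound 2 to compound 4 (within the scatter), also no separation. The clearer step is the loss of a single methoxy, with hydrogen in place of methoxy on an aromatic carbon giving a number 13 percentage points lower from compound 1 to compound 4 (beyond the scatter). No available evidence bears on this result. Whether a hydroxy group or an amine in that methoxy's place would keep the number of compound 1 stays open, as does the ranking of these compounds at other concentrations.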